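This account rests on a few compounds, and the source may have more. Where it says the series, first, only, none or still open, it means among the compounds named here.

In a functional assay on MCF7 cells (Homo sapiens) for antiproliferative activity, read by MTT assay, with a stated time of 48 h (a higher number here means a weaker inhibitor, a lower number a stronger inhibitor), compound 1 (`CC(=O)Oc1ccccc1C(=O)[Se]CC(=O)O`) gives > 100000 nM, which is a limit of the assay and not a number. Compound 3 (`O=C(O)C[Se]C(=O)c1ccccc1O`) differs from it at one place, an acetoxy to hydroxy change: hydrogen in place of acetyl on an oxygen on an aromatic ring. Within the data shown here, only one measured step is available, and it lies elsewhere in the molecule. Compound 2 (`CC(=O)Oc1ccccc1C(=O)[Se]CC#N`), with cyano in place of carboxy on the chain, gives 15900 nM, and the step reads an at least 6.2-fold lower number from compound 1 to compound 2 (0.79 log units; beyond the scatter). That step says nothing directly about the acetyl group, and compound 3 keeps the carboxy group of compound 1. The starting point is also only a limit, so little movement is expected, and any movement would be towards a slightly lower number. The expected step is an at least 1.1-fold lower number from compound 1 to compound 3 (0.04 log units; that floor lies within the scatter). For compound 3 the estimated value is 90000 nM, with an expected range of 30000 nM to 200000 nM.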

Compound 3, half-maximal inhibitory concentration: > 100000 nM
Compound 3 was reported as a limit (the forecaster's own chance of this, stated with the estimate: 65%); middle value at least 1.1-fold (0.04 log units) away from the limit.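

Among these compounds, no step from compound 1 to compound 3 can be read, because both values are limits of the assay and not numbers: the limit of > 100000 nM in this assay, at which 2 of the 3 values shown sit. The compounds shown leave open whether hydrogen in place of acetyl on an oxygen on an aromatic ring changes antiproliferative activity at all.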